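Compound 1 to compound 4: exchange of the pyridyl group

The source may report more compounds than this note shows. Statements on the series, on what has been measured and on what is new or still open speak of the compounds shown alone.

Working notes on three measured analogues and one untested analogue, all read in an in vitro assay on HEK385-7 cells for displacement of a labelled ligand from prostaglandin D2 receptor 2 (Homo sapiens); a higher number here means a weaker inhibitor, a lower number a stronger inhibitor.

Compound 1 `O=C(O)Cc1sc(C(c2ccc(F)cc2)c2ccc(F)cc2)nc1-c1ccnc(N2CCC2)c1` gives 660 nM in this assay. Among the two actual numbers available this is the higher one; the nearest measured neighbour, compound 3 `O=C(O)Cc1sc(C(c2ccccc2)c2ccc(F)c(F)c2)nc1-c1ccc(F)cc1`, gives 10 nM, a gap that lies beyond the usual scatter. Compound 2 `COc1ccc(OC)c(-c2nc(C(c3ccccc3)c3ccccc3)sc2CC(=O)O)c1` gives > 105 nM in this assay, which is a limit of the assay rather than a number (the limit of > 105 nM in this assay, at which 1 of the 3 values shown sits). None of these three compounds differs from another in a single place, so no isolated structural step can be read from the measured set.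

Compound 4 `Nc1cc(-c2nc(C(c3ccc(F)cc3)c3ccc(F)cc3)sc2CC(=O)O)cc(F)n1` is the untested analogue. It differs from compound 1 in one place (2-amino-6-fluoropyridin-4-yl in place of 2-(azetidin-1-yl)pyridin-4-yl on an aromatic carbon). The remainder of compound 1, with the two para-fluorophenyl groups on the shared core and the carboxymethyl group, is kept. For the measured compounds named here, no measured pair isolates a comparable change at this position, so the expected step is uncertain. The step from compound 1 to compound 4 is expected to be a 1.7-fold lower number from compound 1 to compound 4 (0.22 log units; within the scatter), a modest move toward a lower number that may still fall within the scatter. Compound 4 is therefore estimated to give 400 nM in this assay, with a range from 100 nM to 1600 nM.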

Compound 4, half-maximal inhibitory concentration: 220 nM
Estimate against measurement, compound 4: 1.8-fold (0.26 log units) above, within the range that was stated.
By their numbers in this assay, from the lowest: compound 3; then compound 4; then compound 1.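

In this assay, for the compounds shown here, the exchange of 2-(azetidin-1-yl)pyridin-4-yl for 2-amino-6-fluoropyridin-4-yl gives a 3.0-fold lower number from compound 1 to compound 4 (0.48 log units; beyond the scatter) and is the first step that isolates this position, the aromatic carbon next to the ring nitrogen and next to the ring atom that bears a carboxymethyl group. The step shows that this position responds to a change confined to the group on it, with the two para-fluorophenyl groups and the carboxymethyl group kept; the six-membered aromatic ring with one hetero atom stays, the four-membered ring leaves, and the entering group has one hydrogen-bond donor where the leaving group has none. No available evidence gives a measured property that accounts for this step.

The amino group and the fluorine enter together in one step, so their separate shares in the lower number cannot be read from these compounds. Also open, as far as these compounds go, is how this position would respond to a dimethylamino group or a chlorine atom on the same pyridine ring, with the rest of compound 4 kept.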